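The source may hold more compounds than are shown below. What is called first, only, known or untested is meant among the compounds shown, and "the series" means these compounds.

In a functional assay on MDA-MB-468 cells (Homo sapiens) for antiproliferative activity, read by MTT assay, with a stated time of 48 h (on this read-out lower numbers stand for stronger inhibition and higher numbers for weaker inhibition), three compounds sharing one core have been measured: compound 1 `CN(C)CCNc1cc2c(cn1)cc(NC(=O)/C=C/c1ccccc1)c(=O)n2C` gives 12100 nM and compound 2 `CN(C)CCNc1cc2c(cn1)cc(NC(=O)c1ccc(Cl)cc1)c(=O)n2C` gives 1640 nM while compound 3 `COc1ccc(C(=O)Nc2cc3cnc(NCCN(C)C)cc3n(C)c2=O)cc1` gives 15700 nM in the same test. Compound 3 sits at the weak end of this small set, with a 1.3-fold higher number from compound 1 to compound 3 (0.11 log units; within the scatter) and with a 9.6-fold higher number from compound 2 to compound 3 (0.98 log units; beyond the scatter) as the two steps that reach it. Compound 4 `CN(C)CCNc1cc2c(cn1)cc(NC(=O)c1ccncc1)c(=O)n2C` has not been measured yet. Its change is pyridin-4-yl in place of 4-methoxyphenyl on a carbonyl carbon and amounts to pyridin-4-yl in place of 4-methoxyphenyl on a carbonyl carbon. Within the data shown here, no measured compound has a ring with a hetero atom at this place, so no step speaks for it directly. Swaps at this carbonyl carbon can matter, as a 7.4-fold lower number from compound 1 to compound 2 (0.87 log units; beyond the scatter) shows, but that lower number belongs to the chloro compound alone, and compound 4 has no chloro. No step beyond the scatter is therefore expected, in either direction. For compound 4 the expected change is a 1.6-fold lower number from compound 3 to compound 4 (0.20 log units; within the scatter) and no more than that. For compound 4 the estimated value is about 10000 nM with an expected range from 3000 nM to 30000 nM in this assay.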

Compound 4, half-maximal inhibitory concentration: 8360 nM
For compound 4 the middle estimate is 1.2-fold (0.08 log units) above the measured one, within the range that was stated.
By their numbers in this assay, from the lowest: compound 2; then compounds 4, 1 and 3 (each within the scatter of the next).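

Pyridin-4-yl, the first ring with a hetero atom at this carbonyl carbon, falls in with two of the carbon-only groups in this assay: replacing 4-methoxyphenyl gives (a 1.9-fold lower number from compound 3 to compound 4 (0.27 log units; within the scatter)) and replacing 2-phenylethenyl gives (a 1.4-fold lower number from compound 1 to compound 4 (0.16 log units; within the scatter)), so a ring nitrogen here makes no difference beyond the scatter against either compound. Among these compounds, only the step from the chloro compound is larger (a 5.1-fold higher number from compound 2 to compound 4 (0.71 log units; beyond the scatter)), which leaves compound 2 apart from all three others, now including one with a hetero-atom ring. Nothing measured on these compounds explains that difference.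

Going by these compounds, whether the lower number of compound 2 belongs to chloro in particular remains open, and a bromo or fluoro group in its place would test this. A saturated ring such as piperidine on the carbonyl carbon would show whether an aromatic ring is needed here at all.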